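The source may hold more compounds than are shown below. What is called first, only, known or untested is meant among the compounds shown, and "the series" means these compounds.

Three compounds share one core and have each been examined in a functional assay on CCRF-CEM cells (Homo sapiens), read by MTT assay, with a stated time of 72 h; on this read-out lower numbers stand for stronger inhibition and higher numbers for weaker inhibition. Compound 1 `Nc1nc(N)c2c(-c3cc4ccccc4o3)cn([C@@H]3O[C@H](CO)[C@@H](O)[C@H]3O)c2n1` gives only a limit of the assay, > 20000 nM. Compound 2 `O=c1[nH]cnc2c1c(-c1cccs1)cn2[C@@H]1O[C@H](CO)[C@@H](O)[C@H]1O` likewise gives only a limit, > 20000 nM. Compound 3 `Cc1nc(N)c2c(-c3cc4ccccc4o3)cn([C@@H]3O[C@H](CO)[C@@H](O)[C@H]3O)c2n1` also gives only a limit, > 20000 nM. Among the compounds with values here, the single step that can be traced between measured compounds, a step that the two limits leave unreadable from compound 1 to compound 3, has no readable size, since it runs from one limit to another. Compound 3 therefore stands together with the others at the limit, as the limit of > 20000 nM in this assay, at which 3 of the 3 values shown sit, shows for every value recorded.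

Compound 4 `Cc1nc(N)c2c(-c3ccoc3)cn([C@@H]3O[C@H](CO)[C@@H](O)[C@H]3O)c2n1` differs from compound 3 in one place: furan-3-yl in place of 1-benzofuran-2-yl on an aromatic carbon. Within the data shown here, no measured step concerns an exchange of the group on this carbon, and the one traced step gives no size at all. Among the measured compounds shown here, the measured compounds thus offer no direction and no size for the coming step in this assay; all that can be said is that every value so far has sat at the limit, so the expectation is that compound 4 will be found there too or close to it. Compound 4 is expected to give about 25000 nM, within 8000 nM to 80000 nM, most likely again reported as a limit. The step expected is a step that the limit leaves unreadable from compound 3 to compound 4, which is estimated to lie within the usual scatter.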

Compound 4, half-maximal inhibitory concentration: > 100000 nM
Compound 4 was reported as a limit (the forecaster's own chance of this, stated with the estimate: 70%); middle value at least 4.0-fold (0.60 log units) from the limit.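

Compound 3 and compound 4 are each recorded only as a limit in this assay, and no step can be read for the exchange of 1-benzofuran-2-yl for furan-3-yl between them. The compounds shown leave open how strongly any of them inhibits these cells, and whether the group on this aromatic carbon matters at all.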